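This account rests on a few compounds, and the source may have more. Where it says the series, first, only, none or still open, it means among the compounds named here.

In a functional assay on HCC827 cells (Homo sapiens) for inhibition, read by fluorescence, with a stated time of 72 h (a lower number here means a stronger inhibitor of growth, a higher number a weaker inhibitor of growth), compound 1 (`COc1ccc(Cn2cnc3c(Nc4cccc(Cl)c4)nc(N[C@H]4CC[C@H](N)CC4)nc32)cc1`) gives 18700 nM and compound 2 (`COc1cc(Nc2nc(N[C@H]3CC[C@H](N)CC3)nc3c2ncn3CCC(C)C)cc(OC)c1`) gives 11200 nM and these two values lie within the usual scatter of each other. Compound 3 (`CC(C)CCn1cnc2c(Nc3cccc(Cl)c3)nc(N[C@H]3CC[C@H](N)CC3)nc21`) has 3-chlorophenyl in place of 3,5-dimethoxyphenyl on a nitrogen on an aromatic ring when set against compound 2. For the measured compounds named here, no measured pair shows this change alone. Compound 1 also carries 3-chlorophenyl and gives 18700 nM so in this assay no step beyond the scatter is expected, in either direction. The estimated step is a 1.2-fold higher number from compound 2 to compound 3 (0.06 log units; within the scatter) and it remains only an expectation. Compound 3 is estimated at 13000 nM with an expected range (5000 nM to 30000 nM).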

Compound 3, concentration for 50% growth inhibition: 10300 nM
The estimate for compound 3 lay 1.3-fold (0.10 log units) above the measured number, within the range that was stated.
By their numbers in this assay, from the lowest: compounds 3, 2 and 1 (each within the scatter of the next).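

In this assay, 3-chlorophenyl in place of 3,5-dimethoxyphenyl on a nitrogen on an aromatic ring gives a 1.1-fold lower number from compound 2 to compound 3 (0.04 log units; within the scatter), so this exchange of ring substituents leaves the number unmoved beyond the scatter. Isobutyl in place of 4-methoxyphenyl on a saturated chain carbon bound to an aromatic nitrogen gives a 1.8-fold lower number from compound 1 to compound 3 (0.26 log units; within the scatter), so this second place also shows no step beyond the scatter. Nothing shown gives a reason for either result. Still open, as far as these compounds go, is whether an amine or a carboxylic acid on the phenyl ring, or a longer chain in place of isobutyl, would move the number beyond the scatter.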